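Shortening the acyl chain on a chalcone amide

The source may hold more compounds than are shown below. What is called first, only, known or untested is meant among the compounds shown, and "the series" means these compounds.

This study follows a short series of compounds built on one shared core, a chalcone carrying an amide on one of its rings. Compound 1 `COc1cc(/C=C/C(=O)c2cccc(NC(=O)c3c(Cl)cccc3Cl)c2)ccc1O` gives 88% in a functional assay on HUVEC cells (Homo sapiens) for inhibition, tested at 5 ug/mL; a higher number here means a stronger effect of the compound at the concentration tested, a lower number a weaker effect. Compound 2 `COc1cc(/C=C/C(=O)c2cccc(NC(=O)c3cc(Cl)cc(Cl)c3)c2)ccc1O` gives 51% in this assay, and compound 3 `CCCC(=O)Nc1cccc(C(=O)/C=C/c2ccc(O)c(OC)c2)c1` gives 57%. Among these three numbers, compound 3 stands second highest: its value and that of compound 2 lie within the scatter of each other, while compound 1 sits well above both, as seen in a number 31 percentage points lower from compound 1 to compound 3 (beyond the scatter) and a number 6 percentage points higher from compound 2 to compound 3 (within the scatter).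

Compound 4 `COc1cc(/C=C/C(=O)c2cccc(NC(C)=O)c2)ccc1O` has not yet been measured in this assay. It differs from compound 3 in one place: hydrogen in place of ethyl on a saturated chain carbon bound to a carbonyl carbon. The measured steps that come closest both concern the group on this carbonyl carbon. Exchanging the 2,6-dichlorophenyl for propyl gave a number 31 percentage points lower from compound 1 to compound 3 (beyond the scatter), a large drop, whereas exchanging the 3,5-dichlorophenyl for propyl gave a number 6 percentage points higher from compound 2 to compound 3 (within the scatter), within the scatter. Among the measured compounds shown here, no measured step shortens an alkyl chain, so the data give no direct guide for trimming propyl to methyl. Since the step from 3,5-dichlorophenyl to propyl already showed no change beyond the scatter, the expected step of a number 5 percentage points lower from compound 3 to compound 4 (within the scatter) is small, with no clear direction. Compound 4 is therefore estimated at 52%, with a range from 30% to 75%.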

Compound 4, a percentage reported as inhibition, at one concentration (the size of the read-out at that concentration, not a potency): 15%
Beside the measured number, compound 4's estimate is 37 percentage points above it; measured number outside the range, below it.
By their numbers in this assay, from the lowest: compound 4; then compounds 2 and 3 (each within the scatter of the next); then compound 1.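

Shortening propyl to methyl on this carbonyl carbon is the only step shown that changes an alkyl chain, and in this assay it gives a number 42 percentage points lower from compound 3 to compound 4 (beyond the scatter). Among the compounds shown here, this shows that the position is sensitive to the length of the chain, which the earlier compounds could not reveal, since the propyl and 3,5-dichlorophenyl groups had given values within the scatter of each other and so might have suggested a tolerant position. Methyl matches neither of the aryl groups, with a number 36 percentage points lower from compound 2 to compound 4 (beyond the scatter) and a number 73 percentage points lower from compound 1 to compound 4 (beyond the scatter), which leaves compound 4 the lowest of the four and makes the second of these the widest step in the series, while no measurement here explains the loss of inhibition.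

The compounds shown leave open how the read-out changes along the alkyl series, for instance with an ethyl chain between methyl and propyl or with a butyl or longer chain beyond propyl. They also leave open where a plain phenyl group or a chain ending in an amine would fall on this same carbonyl carbon.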